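Extending an alkoxy chain with a carboxylic acid terminus

The source may hold more compounds than are shown below. What is called first, only, known or untested is meant among the compounds shown, and "the series" means these compounds.

Measured compounds:
compound 1 `CCOc1ccc2c(=O)c(-c3ccc(O)cc3)coc2c1` — 80 nM
compound 2 `O=c1c(-c2ccc(O)cc2)coc2cc(OCCCCCCO)ccc12` — 120 nM

In an assay (Cricetulus griseus) for inhibition of aldehyde dehydrogenase, mitochondrial (Homo sapiens) (on this read-out higher numbers stand for weaker inhibition and lower numbers for stronger inhibition), compound 1 gives 80 nM, and compound 2 gives 120 nM; the two numbers sit within the scatter of one another, as the step of a 1.5-fold higher number from compound 1 to compound 2 (0.18 log units; within the scatter) shows. Compound 3 `O=C(O)CCCCCCOc1ccc2c(=O)c(-c3ccc(O)cc3)coc2c1` differs from compound 1 by 4-carboxybutyl in place of hydrogen on a saturated chain carbon, two bonds along the chain from an oxygen on an aromatic ring. Among the compounds with values here, the one step that bears on this, the growth of the chain from compound 1 to compound 2, stayed within the scatter. Compound 3 is therefore expected to land close to compound 1, at 120 nM (range 50 nM to 300 nM), a step of a 1.5-fold higher number from compound 1 to compound 3 (0.18 log units; within the scatter) that is not expected to exceed the scatter.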

Compound 3, half-maximal inhibitory concentration: 50 nM
For compound 3 the middle estimate is 2.4-fold (0.38 log units) above the measured one; measured number inside the range.
By their numbers in this assay, from the lowest: compounds 3, 1 and 2 (each within the scatter of the next, the first and the last beyond it).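

In this assay, the step with the 4-carboxybutyl group is a 1.6-fold lower number from compound 1 to compound 3 (0.20 log units; within the scatter), so a chain ending in a carboxylic acid stays level with the shorter ethyl ether at this position. Within the data shown here, the chain end also matters, which the earlier compounds did not show: carboxy in place of hydroxy gives a 2.4-fold lower number from compound 2 to compound 3 (0.38 log units; beyond the scatter), the only step here beyond the scatter. No measurement on hand explains this step. On these data alone, it remains open whether an amine or a methyl ester at the chain end would match the carboxylic acid, and whether a shorter or longer chain bearing the acid would hold this level.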